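Iodo to nitro swap on a thiosemicarbazone aryl ring

The compounds below may be only part of what the source reports. "The series", "measured", "known", "first", "only" and "open" are said of these compounds alone.

Compound 1 `C/C(=N/NC(=S)Nc1cccc([N+](=O)[O-])c1)c1ccccn1`: 140 nM
Compound 2 `C/C(=N/NC(=S)Nc1ccccc1I)c1ccccn1`: 8.09 nM
Compound 3 `C/C(=N/NC(=S)Nc1cccc(I)c1)c1ccccn1`: 61 nM

Three compounds were measured in a functional assay on T98G cells (Homo sapiens) for cytotoxicity, read by MTT assay, with a stated time of 48 h; on this read-out lower numbers stand for stronger inhibition and higher numbers for weaker inhibition. Compound 2 gives the lowest number; in this assay compound 3 sits at 61 nM and compound 1 at 140 nM. The difference between the cores of compound 2 and compound 3 is not broken down here. Between compound 3 and compound 1 the change is nitro in place of iodo on an aromatic carbon, and it gave a 2.3-fold higher number from compound 3 to compound 1 (0.36 log units; beyond the scatter). Compound 4 `C/C(=N/NC(=S)Nc1ccccc1[N+](=O)[O-])c1ccccn1` has not been measured. It differs from compound 2 by nitro in place of iodo on an aromatic carbon, the same kind of change, though the place now lies ortho to a large group rather than meta to it. Resting on that earlier step, compound 4 is expected to give a 2.5-fold higher number from compound 2 to compound 4 (0.39 log units; beyond the scatter). Compound 4 is estimated at 20 nM, with a range of 6 nM to 70 nM in this assay.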

Compound 4, half-maximal inhibitory concentration: 6.61 nM
Compound 4: the middle estimate sits 3.0-fold (0.48 log units) above what was measured; the range from low to high includes it.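

In this assay nitro in place of iodo gave a 1.2-fold lower number from compound 2 to compound 4 (0.09 log units; within the scatter) and so left compound 2 and compound 4 level within the scatter. The change therefore did not carry over at the same size from one core to the other: the same change on two cores in this assay, a 2.3-fold higher number (0.36 log units; beyond the scatter) from compound 3 to compound 1 and a 1.2-fold lower number (0.09 log units; within the scatter) from compound 2 to compound 4, 2.8-fold (0.45 log units) apart, beyond the scatter of two such steps. This shows that the step cannot simply be transferred between these two cores, but two pairs set no rule for the series and do not show why the steps differ.

The compounds shown leave open whether an amine or a carboxylic acid in place of iodo would give a step like either of these. They also leave open how the two steps would compare in any other assay.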